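Fluoro to chloro on the benzothiazole: what to expect

A few compounds are considered here, and "the series" means these few. Any claim that something is new, unique, unknown or untested is made for them only; others in the source may bear on it.

Measured so far:
compound 1, `COc1cccc(OC)c1C(=O)N1C[C@@H]2CN(c3nc4ccc(Cl)cc4s3)C[C@@H]2C1`, 2200 nM
compound 2, `COc1ccc(C(=O)N2C[C@@H]3CN(c4nc5ccc(F)cc5s4)C[C@@H]3C2)c(OC)c1`, 746 nM

Both compounds were tested in an assay on isolated protein for binding affinity to Orexin receptor type 2 (Homo sapiens); on this read-out higher numbers stand for weaker inhibition and lower numbers for stronger inhibition. Compound 2 gives the lowest of the two numbers; compound 1 has the higher one, and the gap between them lies beyond the scatter. Among the compounds with values here, the two differ in more than one place, so the comparison shows only that compound 2 stands stronger.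

Compound 3 is `COc1ccc(C(=O)N2C[C@@H]3CN(c4nc5ccc(Cl)cc5s4)C[C@@H]3C2)c(OC)c1`. It keeps everything of compound 2 except for one change: chloro in place of fluoro on an aromatic carbon, the same difference cut one bond further out reading 6-fluoro-1,3-benzothiazol-2-yl to 6-chloro-1,3-benzothiazol-2-yl. Within the data shown here, no single-change step between measured compounds shows what this swap does here, so the step is expected to stay within the scatter, with no direction beyond it: a 1.1-fold lower number from compound 2 to compound 3 (0.03 log units; within the scatter). Compound 3 is therefore estimated at 700 nM in this assay, between 250 nM and 2000 nM.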

Compound 3, inhibition constant: 510 nM
Beside the measured number, compound 3's estimate is 1.4-fold (0.14 log units) above it; the range from low to high includes it.
By their numbers in this assay, from the lowest: compounds 3 and 2 (each within the scatter of the next); then compound 1.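

In this assay, going from 6-fluoro-1,3-benzothiazol-2-yl to 6-chloro-1,3-benzothiazol-2-yl gives a 1.5-fold lower number from compound 2 to compound 3 (0.17 log units; within the scatter), so this read-out does not separate chloro from fluoro on this aromatic carbon with the 2,4-dimethoxyphenyl amide in place. With chloro held constant, 2,4-dimethoxyphenyl in place of 2,6-dimethoxyphenyl on the carbonyl carbon gives a 4.3-fold lower number from compound 1 to compound 3 (0.63 log units; beyond the scatter), the only one of the two single-change steps that lies beyond the scatter, which points to the dimethoxyphenyl pattern rather than the halogen as the change that registers here. Nothing available explains either step.

Still open, going by these compounds, is how hydrogen, methoxy or an amine would read on the same aromatic carbon. Also open, on these data alone, is whether the dimethoxyphenyl step holds with fluoro in place of chloro.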